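From 1H-benzimidazol-2-yl to Benzyl on a Sulfur Chain

A few compounds are considered here, and "the series" means these few. Any claim that something is new, unique, unknown or untested is made for them only; others in the source may bear on it.

Among the measured compounds shown here, in a toxicity assay on GES1 cells (Homo sapiens) for inhibition, read by MTT assay, with a stated time of 72 h (a higher number here means a weaker inhibitor, a lower number a stronger inhibitor), compound 1 `Cc1cc(N2CC[C@@H](C)[C@@H](N(C)c3ncnc4[nH]ccc34)C2)n2nc(SCc3nc4ccccc4[nH]3)nc2n1` gives 40200 nM, the only exact number available so far. Compound 2 `C[C@@H]1CCN(c2cc(-c3ccccc3)nc3ncnn23)C[C@@H]1N(C)c1ncnc2[nH]ccc12` is reported only as a limit, > 100000 nM. Compound 3 `Cc1cc(N2CC[C@@H](C)[C@@H](N(C)c3ncnc4[nH]ccc34)C2)n2nc(SCCc3ccccc3)nc2n1` has not yet been measured in this assay. It differs from compound 1 through benzyl in place of 1H-benzimidazol-2-yl on a saturated chain carbon bound to a sulfur. Read one bond further out, (1H-benzimidazol-2-yl)methyl gives way to phenethyl. For the measured compounds named here, no measured pair yet shows what such a change does. With compound 1 at 40200 nM as the sole numeric anchor, only a small shift towards weaker inhibition is expected in this assay, possibly none beyond the scatter. The expected step is a 1.2-fold higher number from compound 1 to compound 3 (0.09 log units; within the scatter). For compound 3 the estimated value is 50000 nM, with an expected range of 18000 nM to 100000 nM.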

Compound 3, half-maximal inhibitory concentration: 66200 nM
Compound 3: middle estimate off by 1.3-fold (0.12 log units), on the low side; the measured number falls inside the stated range.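

In this assay, among the compounds shown here, the pair gives the first measured step at this place, on a saturated chain carbon bound to a sulfur: benzyl in place of 1H-benzimidazol-2-yl gives a 1.6-fold higher number from compound 1 to compound 3 (0.22 log units; within the scatter). The exchange removes the five-membered aromatic ring with its two nitrogens, along with the hydrogen-bond donor and acceptor counted for 1H-benzimidazol-2-yl, yet the two readings cannot be told apart in this assay. Compound 2 is reported only as a limit of the assay and supplies no step: the limit of > 100000 nM in this assay, at which 1 of the 3 values shown sits.

On these data alone, it remains open whether any group at this place can move the reading in this assay beyond the scatter. An amine or a carboxylic acid on the sulfur chain, or a longer chain ending in phenyl, would be among the groups still to be read there.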